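A few compounds are considered here, and "the series" means these few. Any claim that something is new, unique, unknown or untested is made for them only; others in the source may bear on it.

Of the compounds shown here, two that share one core have been measured so far. Compound 1 `O=C(c1ccccn1)N1CCCn2nc(COc3ccccc3)cc21` gives 44% in a functional assay on HEK293 cells for positive allosteric modulation of metabotropic glutamate receptor 5 (Homo sapiens), read by calcium flux; on this read-out lower numbers stand for smaller maximal responses and higher numbers for larger maximal responses. Compound 2 `CC(=O)N1CCCn2nc(COc3ccccc3F)cc21` gives 60% in this assay, the higher of the two numbers, with compound 1 sitting beyond the scatter below it. Compound 3 `CC(=O)N1CCCn2nc(COc3ccc(F)cc3)cc21` has not yet been measured. It differs from compound 2 in one spot only: 4-fluorophenyl in place of 2-fluorophenyl on an oxygen on a saturated carbon. Within the data shown here, no measured pair shows this kind of change, so a small step, near the scatter and leaning slightly downward, is expected: a number 5 percentage points lower from compound 2 to compound 3 (within the scatter). Compound 3 is therefore estimated at 55%, most likely between 35% and 78%.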

Compound 3, largest response reached (reported as percent of maximum), in percent of the reference or control that the assay uses: 56%
Compound 3: the middle estimate sits 1 percentage points below what was measured; measured number inside the range.
By their numbers in this assay, from the lowest: compound 1; then compounds 3 and 2 (each within the scatter of the next).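

Swapping 2-fluorophenyl for 4-fluorophenyl on the oxygen gives a number 4 percentage points lower from compound 2 to compound 3 (within the scatter) in this assay, so this read-out does not separate these two groups at this position. Among these compounds, this is the first single-place comparison, and it shows that this change to the fluorophenyl group leaves the maximal response within the usual scatter. Nothing available explains this result. Still open, going by these compounds, is whether 3-fluorophenyl, or a chlorine or methoxy group in place of the fluorine, would give a response beyond the scatter. Also open, on these data alone, is how the unsubstituted phenyl group compares with these fluorophenyl groups on the same core.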